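The compounds below may be only part of what the source reports. "The series", "measured", "known", "first", "only" and "open" are said of these compounds alone.

Measured compounds:
compound 1 `COc1ccc(-c2nc(SCC3C[C@](C)(O)CC(=O)O3)[nH]c2-c2ccc(OC)cc2)cc1` gives 420 nM
compound 2 `CO[C@]1(C)C[C@H](O)C[C@@H](CSc2nc(-c3ccccc3)c(-c3ccccc3)[nH]2)O1` gives 30 nM
compound 3 `O=C1CC(O)CC(CSc2nc(-c3ccccc3)c(-c3ccccc3)[nH]2)O1` gives 910 nM

In an assay on microsomes from liver for inhibition of sterol O-acyltransferase 1 (Rattus norvegicus) (a higher number here means a weaker inhibitor, a lower number a stronger inhibitor), compound 3 stands at the highest number of the three, beyond the scatter from compound 1 and far beyond it from compound 2, so it is the weakest inhibitor of the set. Compound 4 `COC(CSc1nc(-c2ccccc2)c(-c2ccccc2)[nH]1)OC` is the next step from compound 3: a group of 5 heavy atoms (3 carbon, 2 oxygen; no ring) in place of a group of 8 heavy atoms (5 carbon, 3 oxygen; one six-membered non-aromatic ring with 1 hetero atom), on a saturated chain carbon bound to a sulfur. For the measured compounds named here, no measured pair covers a change of this kind, so the direction rests on compound 3 alone. With the ring removed, a step toward a somewhat higher number in this assay is expected for compound 4, though it may also stay within the scatter. Compound 4 is expected to give 1500 nM, plausibly between 400 nM and 6000 nM, an expected change of a 1.6-fold higher number from compound 3 to compound 4 (0.22 log units; within the scatter).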

Compound 4, half-maximal inhibitory concentration: 580 nM
Compound 4: the middle estimate sits 2.6-fold (0.41 log units) above what was measured; measured number inside the range.
By their numbers in this assay, from the lowest: compound 2; then compounds 1, 4 and 3 (each within the scatter of the next, the first and the last beyond it).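

In this assay the dimethoxymethyl group replaces the six-membered ring on a saturated chain carbon bound to a sulfur (a 1.6-fold lower number from compound 3 to compound 4 (0.20 log units; within the scatter)). At this place, therefore, the ring and its hydrogen-bond donor are not needed to hold the level of inhibition seen with compound 3. No measurement shown accounts for this result.

On these data alone, an amine, a carboxylic acid or a longer chain at this place remains open. The ring and the hydrogen-bond donor leave together in this single step, so their separate contributions cannot be told apart.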